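Compound 4 drops the ring methyl of compound 3

The source may hold more compounds than are shown below. What is called first, only, known or untested is meant among the compounds shown, and "the series" means these compounds.

Measured so far in a functional assay on cells for agonist activity at Free fatty acid receptor 1 (Mus musculus), read by FLIPR and calcium flux, with a stated time of 100 s; on this read-out lower numbers stand for an effect already at smaller amounts and higher numbers for an effect only at larger amounts of compound:
compound 1 `Cc1ccccc1Oc1ccc(N2C[C@@H](C(F)(F)F)C[C@H]2CC(=O)O)cc1`, 330 nM
compound 2 `Cc1ccccc1COc1ccc(N2CCC[C@H]2CC(=O)O)cc1`, 3400 nM
compound 3 `Cc1ccccc1Oc1ccc(N2CCC[C@H]2CC(=O)O)cc1`, 5600 nM

Compound 3 has the highest number of the three. Against compound 2 the gap is small: a 1.6-fold higher number from compound 2 to compound 3 (0.22 log units; within the scatter). Against compound 1 it is large: a 17-fold higher number from compound 1 to compound 3 (1.23 log units; beyond the scatter).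

Compound 4 `O=C(O)C[C@@H]1CCCN1c1ccc(Oc2ccccc2)cc1` is still to be measured in this assay. It differs from compound 3 by hydrogen in place of methyl on an aromatic carbon: the methyl, one heavy atom, leaves the six-membered aromatic ring of carbon only, where it sat ortho to a large group; cut one bond further out, the change reads 2-methylphenyl to phenyl.

For the measured compounds named here, no measured step removes this methyl, so the expectation rests on analogy. The step of a 1.6-fold higher number from compound 2 to compound 3 (0.22 log units; within the scatter) reshaped the same terminal ring, and the number barely moved. The step of a 17-fold higher number from compound 1 to compound 3 (1.23 log units; beyond the scatter) removed a group on the saturated ring, a different place, and moved the number a great deal. Taking off a single methyl from the terminal ring looks closer to the first kind of change. For compound 4 the expected step is small, if anything upward: a 1.3-fold higher number from compound 3 to compound 4 (0.10 log units; within the scatter). Compound 4 is therefore estimated at about 7000 nM, within 3000 nM to 18000 nM.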

Compound 4, half-maximal effective concentration: > 16000 nM
Compound 4 gave a limit, no number; the forecaster's own chance of this, stated with the estimate: 10%; middle value at least 2.2-fold (0.35 log units) away from the limit.
By their numbers in this assay, from the lowest: compound 1; then compounds 2 and 3 (each within the scatter of the next). At a limit, above all of these: compound 4.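

In this assay compound 4 gives > 16000 nM, which is a limit of the assay and not a number. The methyl on the aromatic carbon therefore counts in this series: an at least 2.8-fold higher number from compound 3 to compound 4 (0.45 log units; beyond the scatter), whereas the earlier change at the same end of the molecule, a 1.6-fold higher number from compound 2 to compound 3 (0.22 log units; within the scatter), stayed small. The phenyl compound also separates from the 2-methylbenzyl compound, with an at least 4.7-fold higher number from compound 2 to compound 4 (0.67 log units; beyond the scatter), so this end of the series is not indifferent to change, and the loss of a single carbon is enough to show it; both new steps are open-ended in size: the limit of > 16000 nM in this assay, at which 1 of the 4 values shown sits.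

Open, as far as these compounds go, is whether the methyl itself is needed on that aromatic carbon or whether another small group, such as chlorine, fluorine or methoxy, would serve in its place. Also open, from the compounds shown here alone, is whether trifluoromethyl on the saturated ring carbon, which separates compound 1 from compound 3 by a 17-fold higher number from compound 1 to compound 3 (1.23 log units; beyond the scatter), gives a comparable step when the terminal ring is phenyl rather than 2-methylphenyl.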